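The source may report more compounds than this note shows. Statements on the series, on what has been measured and on what is new or still open speak of the compounds shown alone.

Working notes on the series. All three measured compounds share one core and differ only in the aryl group on the amine nitrogen. Compound 1 `C=C1[C@@H](OC(C)=O)C[C@@H]2[C@](C)(CO[Si](C)(C)C(C)(C)C)[C@H](OC(C)=O)CC[C@@]2(C)[C@@H]1C[C@@H](Nc1ccc(C(=O)O)cc1)C1=CCOC1=O` carries a 4-carboxyphenyl group; in a functional assay on HT-29 cells (Homo sapiens) for cytotoxicity, read by sulforhodamine B assay (a higher number here means a weaker inhibitor, a lower number a stronger inhibitor), compound 1 gives 4630 nM. Compound 2 `C=C1[C@@H](OC(C)=O)C[C@@H]2[C@](C)(CO[Si](C)(C)C(C)(C)C)[C@H](OC(C)=O)CC[C@@]2(C)[C@@H]1C[C@@H](Nc1cccc2ccccc12)C1=CCOC1=O` carries a naphthalen-1-yl group; in this assay compound 2 gives 15000 nM. Compound 3 `C=C1[C@@H](OC(C)=O)C[C@@H]2[C@](C)(CO[Si](C)(C)C(C)(C)C)[C@H](OC(C)=O)CC[C@@]2(C)[C@@H]1C[C@@H](Nc1ccc(F)cc1)C1=CCOC1=O` carries a 4-fluorophenyl group; in this assay compound 3 gives 4940 nM, the second highest of the three numbers, with compound 1 nearest (a 1.1-fold higher number from compound 1 to compound 3 (0.03 log units; within the scatter)) and compound 2 furthest (a 3.0-fold lower number from compound 2 to compound 3 (0.48 log units; beyond the scatter)).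

Compound 4 `C=C1[C@@H](OC(C)=O)C[C@@H]2[C@](C)(CO[Si](C)(C)C(C)(C)C)[C@H](OC(C)=O)CC[C@@]2(C)[C@@H]1C[C@@H](Nc1ccc(O)cc1)C1=CCOC1=O` differs from compound 3 by hydroxy in place of fluoro on an aromatic carbon. For the measured compounds named here, the one measured step that bears on this is the earlier swap at the same aromatic carbon, a 1.1-fold higher number from compound 1 to compound 3 (0.03 log units; within the scatter), which stayed within the scatter. The other steps, a 3.2-fold higher number from compound 1 to compound 2 (0.51 log units; beyond the scatter) and a 3.0-fold lower number from compound 2 to compound 3 (0.48 log units; beyond the scatter), exchange the whole aryl group and are modest in size. A step no larger than the scatter is therefore expected in this assay, with no direction favoured. Compound 4 is expected to give 5000 nM, in the range 2500 nM to 10000 nM. The expected step is a 1.0-fold higher number from compound 3 to compound 4 (0.01 log units; within the scatter).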

Compound 4, half-maximal inhibitory concentration: 6140 nM
Beside the measured number, compound 4's estimate is 1.2-fold (0.09 log units) below it; low and high end bracket the measured number.
By their numbers in this assay, from the lowest: compounds 1, 3 and 4 (each within the scatter of the next); then compound 2.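

At the aromatic carbon para to a large group, in this assay, hydroxy brings a hydrogen-bond donor and acceptor where fluoro has none, yet the step stays small, a 1.2-fold higher number from compound 3 to compound 4 (0.09 log units; within the scatter), and hydroxy in place of carboxy at the same carbon also stays within the scatter, a 1.3-fold higher number from compound 1 to compound 4 (0.12 log units; within the scatter). Carboxy, fluoro and hydroxy at this carbon therefore give numbers that cannot be told apart, while exchanging naphthalen-1-yl for 4-hydroxyphenyl gives a step beyond the scatter, a 2.4-fold lower number from compound 2 to compound 4 (0.39 log units; beyond the scatter), the same kind of separation seen with the other two phenyl groups. Nothing measured here offers a reason for these numbers.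

As far as these compounds go, whether an amine, a methoxy group or a longer chain at this carbon would also stay within the scatter remains open. Also open, from the compounds shown here alone, is whether hydroxy or fluoro on another carbon of the ring would give the same result.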